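Halogen swap on an inactive pyrazole-diamine series

The source may report more compounds than this note shows. Statements on the series, on what has been measured and on what is new or still open speak of the compounds shown alone.

Measured so far, in an assay on isolated protein for binding affinity to 5-hydroxytryptamine receptor 1E (Homo sapiens); on this read-out lower numbers stand for stronger inhibition and higher numbers for weaker inhibition:

Compound 1, `Clc1ccc(-c2n[nH]cc2N2CCCNCC2)cc1`, gives > 10000 nM, which is a limit of the assay and not a number.
Compound 2, `Fc1ccc(-c2n[nH]cc2N2CCCNCC2)cc1`, gives > 10000 nM, again a limit of the assay.
Compound 3, `Clc1cccc(-c2n[nH]cc2N2CCNCC2)c1`, gives > 10000 nM, also a limit of the assay.

All three values sit at the limit of > 10000 nM in this assay, at which 3 of the 3 values shown sit, so none of them is a number that can be compared. Compound 1 and compound 2 differ by fluoro in place of chloro on an aromatic carbon. The step that the two limits leave unreadable from compound 1 to compound 2 therefore cannot be read, because both ends are limits. Compound 3 carries a different core, and the difference between the core of compound 1 and the core of compound 3 is not broken down here.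

Compound 4, `Fc1cccc(-c2n[nH]cc2N2CCNCC2)c1`, has not yet been measured. It differs from compound 3 by fluoro in place of chloro on an aromatic carbon. This is the same kind of change as that from compound 1 to compound 2, though the place differs: there the new group stands para to a large group, here meta to a large group.

For the measured compounds named here, since the only precedent for this change, the step from compound 1 to compound 2, is unreadable, and since compound 3 itself reaches only a limit in this assay, compound 4 is expected to behave the same way. The expected step that the limit leaves unreadable from compound 3 to compound 4 is thus small, resting on the limit of compound 3 and on the limits of compound 1 and compound 2. Compound 4 is expected to give about 15000 nM in this assay, most likely reported as a limit again, with a range from 4000 nM to 60000 nM.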

Compound 4, inhibition constant: > 10000 nM
Compound 4 gave a limit, no number; the forecaster's own chance of this, stated with the estimate: 85%; the middle value does not contradict the limit.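

In this assay compound 4 gives > 10000 nM as a limit of the assay, not a number. Compound 3 also stands at a limit, so no new step can be read from compound 3 to compound 4, and all the values remain at one limit: the limit of > 10000 nM in this assay, at which 4 of the 4 values shown sit. The compounds shown leave open how far each lies beyond that limit, and whether fluoro in place of chloro changes the read-out at all.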